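The source may hold more compounds than are shown below. What is called first, only, known or untested is meant among the compounds shown, and "the series" means these compounds.

Among the compounds with values here, compound 1 `C[C@H](c1ccc(-c2cc(Cl)ccc2-c2nc(=O)o[nH]2)cc1)N(CC1CC1)c1nc2c(C(=O)O)cccc2o1` stands at the top of the three compounds measured so far in an ADME assay on the whole organism (Macaca fascicularis) for pharmacokinetics, read by LC-MS, using cassette dosing, at a dose of 1 mg/kg by the oral route; on this read-out higher numbers stand for higher exposure at the dose given and lower numbers for lower exposure. Compound 1 gives 976 nM. Compound 2 `CCCCN(c1nc2c(C(=O)O)cccc2o1)[C@H](C)c1ccc(-c2ccccc2-c2nnn[nH]2)cc1` gives 238 nM in this assay, and compound 3 `CCCCN(c1nc2c(NS(C)(=O)=O)cccc2o1)[C@H](C)c1ccc(-c2ccccc2-c2nnn[nH]2)cc1` gives 49.9 nM in this assay, so compound 1 lies beyond the scatter above both of them. Within the data shown here, the only single-point step among the measured compounds is a 4.8-fold lower number from compound 2 to compound 3 (0.68 log units; beyond the scatter), which concerns methanesulfonamido in place of carboxy on an aromatic carbon, a change at a different part of the shared core than the one now considered.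

Compound 4 `Cc1ccc(-c2nc(=O)o[nH]2)c(-c2ccc([C@@H](C)N(CC3CC3)c3nc4c(C(=O)O)cccc4o3)cc2)c1` differs from compound 1 by methyl in place of chloro on an aromatic carbon of a six-membered aromatic ring of carbon only, meta to a large group and para to a group of 6 heavy atoms. Among the measured compounds shown here, no measured step covers an exchange of chloro for methyl; the step from compound 2 to compound 3 alters another group and gives no direct guide. With nothing bearing on it, the account expects no step beyond the scatter, so compound 4 is expected to show a 1.1-fold lower number from compound 1 to compound 4 (0.04 log units; within the scatter). Compound 4 is therefore estimated at 900 nM in this assay, with a range from 350 nM to 2300 nM.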

Compound 4, maximal plasma concentration: 2920 nM
Compound 4: the middle estimate sits 3.2-fold (0.51 log units) below what was measured; the measured number lies above the stated range.
By their numbers in this assay, from the lowest: compound 3; then compound 2; then compound 1; then compound 4.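

In this assay the exchange of chloro for methyl gives a 3.0-fold higher number from compound 1 to compound 4 (0.48 log units; beyond the scatter) on an aromatic carbon meta to a large group and para to a group of 6 heavy atoms, the first step among the compounds shown to touch this position. It shows that replacing one heavy atom with another at this place can move the read-out beyond the scatter, although neither group has hydrogen-bond donors, hydrogen-bond acceptors or a net charge. Nothing available on either group bears on this step.

This rests on a single pair, so the compounds shown leave open how other groups at the same place, such as fluoro, methoxy or trifluoromethyl, would stand against chloro and methyl. They also leave open whether the exchange of chloro for methyl would give a step of similar size and direction on a compound carrying the butyl chain in place of the cyclopropylmethyl group, or a tetrazole in place of the ring that compound 1 and compound 4 share.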